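Series notes: from compound 2 to compound 3

A few compounds are considered here, and "the series" means these few. Any claim that something is new, unique, unknown or untested is made for them only; others in the source may bear on it.

Within the data shown here, compound 2 `C[n+]1ccn(CCCC(C)(C)[N+](=O)[O-])c1/C=N/O` stands highest of the two numbers so far in a physicochemical assay for lipophilicity (on this read-out lower numbers stand for lower lipophilicity and higher numbers for higher lipophilicity), giving -2.18. Among the measured compounds shown here, its only measured neighbour, compound 1 `CN(CCCn1cc[n+](C)c1/C=N/O)S(C)(=O)=O`, gives -2.63 in this assay, and the step of a number 0.45 log units higher from compound 1 to compound 2 (beyond the scatter) is the one measured step. That step exchanges a group three bonds along the chain from an aromatic nitrogen and does not touch the place changed below.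

Compound 3 `CC[n+]1ccn(CCCC(C)(C)[N+](=O)[O-])c1/C=N/O` differs from compound 2 by methyl in place of hydrogen on a saturated chain carbon bound to an aromatic nitrogen. For the measured compounds named here, no measured step covers this kind of addition, so nothing measured here points firmly either way; the expectation rests only on the entering group being one carbon with no donors, acceptors or charge. The step of a number 0.33 log units higher from compound 2 to compound 3 (beyond the scatter) is therefore expected to be small and upward, likely beyond the scatter but not by much. For compound 3 the estimate in this assay is -1.85, with a range from -2.25 to -1.45.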

Compound 3, distribution coefficient: -1.8
For compound 3 the middle estimate is 0.05 log units below the measured one; the measured number falls inside the stated range.
By their numbers in this assay, from the lowest: compound 1; then compound 2; then compound 3.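

In this assay, among these compounds, the change from methyl to ethyl, which is methyl in place of hydrogen on a saturated chain carbon bound to an aromatic nitrogen, gives a number 0.38 log units higher from compound 2 to compound 3 (beyond the scatter) and is the first measured step at this place. The earlier pair showed movement only at the other end of the chain, with a number 0.45 log units higher from compound 1 to compound 2 (beyond the scatter) for the exchange three bonds along the chain from an aromatic nitrogen, so the read-out now shifts by a step printed as modest at each of the two places changed, and the 1-methyl-1-nitroethyl group stays the same across the new step. Nothing measured on these compounds accounts for the size or direction of the new step.

As far as these compounds go, a single addition at this place gives one step and no trend, so it remains open whether a longer chain such as propyl, or a chain ending in a hydroxyl group or an amine, would continue in the same direction. From the compounds shown here alone, it also remains open whether the same step would appear with the methyl(methylsulfonyl)amino group of compound 1 in place of the 1-methyl-1-nitroethyl group.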